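Compound 4 after a small set of three

A few compounds are considered here, and "the series" means these few. Any claim that something is new, unique, unknown or untested is made for them only; others in the source may bear on it.

Values so far in a functional assay on MCF7 cells (Homo sapiens) for antiproliferative activity, read by MTT assay; a higher number here means a weaker inhibitor, a lower number a stronger inhibitor:
Compound 1 `COc1cc2c(Oc3ccc(NC(=O)Nc4ccccc4C(F)(F)F)cc3)ccnc2cc1OCCCCCCC(=O)NO` gives 1080 nM
Compound 2 `COc1cc2c(Oc3ccc(NC(=O)N/N=C/c4ccccc4)cc3)ccnc2cc1OCCCCCCC(=O)NO` gives 610 nM
Compound 3 `COc1cc2c(Oc3ccc(NC(=O)N/N=C/c4ccc(F)cc4)cc3)ccnc2cc1OCCCCCCC(=O)NO` gives 1360 nM

Compound 3 cannot be told apart from compound 1 (step: a 1.3-fold higher number from compound 1 to compound 3 (0.10 log units; within the scatter)), but its number lies modestly above that of compound 2 (step: a 2.2-fold higher number from compound 2 to compound 3 (0.35 log units; beyond the scatter)). Going to compound 4 `COc1cc2c(Oc3ccc(NC(=O)NNC(=O)c4cccc(C)c4)cc3)ccnc2cc1OCCCCCCC(=O)NO` means a group of 10 heavy atoms (8 carbon, 1 nitrogen, 1 oxygen; one six-membered aromatic ring of carbon only) in place of a group of 9 heavy atoms (7 carbon, 1 nitrogen, 1 fluorine; one six-membered aromatic ring of carbon only), on an amide-type nitrogen and the new group is ((3-methylphenyl)carbonyl)amino. Exchanges on that amide-type nitrogen (steps: a 1.8-fold lower number from compound 1 to compound 2 (0.25 log units; within the scatter) and a 1.3-fold higher number from compound 1 to compound 3 (0.10 log units; within the scatter)) stayed within the scatter. Among the compounds with values here, no measured compound carries the new group. In this assay no change beyond the scatter is therefore expected (estimated: a 1.4-fold lower number from compound 3 to compound 4 (0.13 log units; within the scatter)). For compound 4 the estimated value is 1000 nM (expected range 400 nM to 2500 nM).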

Compound 4, half-maximal inhibitory concentration: 5830 nM
Compound 4: middle estimate off by 5.8-fold (0.77 log units), on the low side, and the stated range ends below it.
By their numbers in this assay, from the lowest: compounds 2, 1 and 3 (each within the scatter of the next, the first and the last beyond it); then compound 4.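

In this assay, compound 4 is the weakest of the four, standing beyond the scatter from each of the others (a 4.3-fold higher number from compound 3 to compound 4 (0.63 log units; beyond the scatter)) (a 9.6-fold higher number from compound 2 to compound 4 (0.98 log units; beyond the scatter)) (a 5.4-fold higher number from compound 1 to compound 4 (0.73 log units; beyond the scatter)). The amide-type nitrogen therefore does not accept every aromatic group equally, and ((3-methylphenyl)carbonyl)amino is clearly the worst group seen there. No available evidence explains this loss.

The compounds shown leave open whether the loss follows from the carbonyl with its added hydrogen-bond donor or from the methyl. A plain (phenylcarbonyl)amino group would separate these two.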